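The source may hold more compounds than are shown below. What is called first, only, known or untested is meant among the compounds shown, and "the series" means these compounds.

Compound 1, `CN(C)CCC1=C(C(c2ccccc2)c2ccccn2)c2ccccc2C1`, is the stronger of the two measured compounds in an assay on CHO-K1 cells for binding affinity to muscarinic acetylcholine receptor M5 (Homo sapiens) (a lower number here means a stronger inhibitor, a higher number a weaker inhibitor), where compound 1 gives 66.1 nM. Its partner compound 2, `CN(C)CCC1=C(Cc2ccccn2)c2ccccc2C1`, gives 3630 nM in this assay. For the measured compounds named here, the single step between them, hydrogen in place of phenyl on a saturated chain carbon bound to an aromatic carbon and a double-bonded ring carbon, produced a 55-fold higher number from compound 1 to compound 2 (1.74 log units; beyond the scatter), so removing one of the two aromatic groups on that carbon weakened binding sharply.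

Compound 3, `CC(C1=C(CCN(C)C)Cc2ccccc21)c1ccccc1`, has not been measured. It differs from compound 1 by methyl in place of pyridin-2-yl on a saturated chain carbon bound to an aromatic carbon and a double-bonded ring carbon. Going by the values given here, the one measured step bears on it directly, since it also strips an aromatic ring from the same carbon and gave a 55-fold higher number from compound 1 to compound 2 (1.74 log units; beyond the scatter). A similar loss is therefore expected, a 30-fold higher number from compound 1 to compound 3 (1.48 log units; beyond the scatter). Compound 3 is estimated at 2000 nM, with a likely range from 400 nM to 10000 nM.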

Compound 3, inhibition constant: 309 nM
Compound 3: the middle estimate sits 6.5-fold (0.81 log units) above what was measured; the measured number lies below the stated range.
By their numbers in this assay, from the lowest: compound 1; then compound 3; then compound 2.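

With methyl in place of pyridin-2-yl, this assay shows a 4.7-fold higher number from compound 1 to compound 3 (0.67 log units; beyond the scatter), so the loss is real but modest, and compound 3 keeps much of the binding of compound 1 with only phenyl left as an aromatic group on this carbon. The earlier step, a 55-fold higher number from compound 1 to compound 2 (1.74 log units; beyond the scatter), costs clearly more, which suggests that the two aromatic groups on this carbon do not count equally, although hydrogen and methyl also differ as the groups that enter. No measurement here accounts for the size of either loss.

The compounds shown cannot separate the effect of the ring that leaves from that of the group that enters. As far as these compounds go, it also remains open how binding responds to ethyl, or to an amine, in place of pyridin-2-yl on this carbon.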